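Pyridinylpiperazine in Place of Piperidine: An Expected Value

The source may hold more compounds than are shown below. What is called first, only, known or untested is meant among the compounds shown, and "the series" means these compounds.

Compound 2 `COc1ccc(NC(=O)Nc2nc(Sc3c[nH]c4ccccc34)cc(N3CCCCC3)n2)cc1` gives 17100 nM in a functional assay on HepG2 cells (Homo sapiens) for inhibition, with a stated time of 72 h (on this read-out higher numbers stand for weaker inhibition and lower numbers for stronger inhibition), the highest of the two numbers shown. Compound 1 `Cc1cc(Cl)ccc1NC(=O)Nc1nc(Sc2c[nH]c3ccccc23)cc(N2CCN(Cc3ccccc3)CC2)n1` gives 11700 nM in this assay, and the two values lie within the scatter of each other. Compound 3 `COc1ccc(NC(=O)Nc2nc(Sc3c[nH]c4ccccc34)cc(N3CCN(c4ccccn4)CC3)n2)cc1` differs from compound 2 by 4-(pyridin-2-yl)piperazin-1-yl in place of piperidin-1-yl on an aromatic carbon. Going by the values given here, no step between measured compounds covers this change. The values of compound 1 and compound 2 already show that a different group at this place need not move the number beyond the scatter, and no step beyond it is expected here. Compound 3 is therefore estimated at 13000 nM, with a range from 4500 nM to 40000 nM, a step of a 1.3-fold lower number from compound 2 to compound 3 (0.12 log units; within the scatter) that is expected to stay within the scatter.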

Compound 3, half-maximal inhibitory concentration: 11400 nM
Beside the measured number, compound 3's estimate is 1.1-fold (0.06 log units) above it, and the stated range covers the measured number.
By their numbers in this assay, from the lowest: compounds 3, 1 and 2 (each within the scatter of the next).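

In this assay, going by these compounds alone, the change from piperidin-1-yl to 4-(pyridin-2-yl)piperazin-1-yl gives the first step between compounds differing in one place (a 1.5-fold lower number from compound 2 to compound 3 (0.18 log units; within the scatter)). At this aromatic carbon next to the ring nitrogen, the larger group with its added pyridine ring therefore leaves the number within the scatter. Nothing given here explains this result.

Going by these compounds, whether a morpholine, a dimethylamino group or a piperazine bearing a carboxylic acid at this place would move the number beyond the scatter remains open. So does whether 4-(pyridin-2-yl)piperazin-1-yl behaves alike with the aryl group of compound 1.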